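This account rests on a few compounds, and the source may have more. Where it says the series, first, only, none or still open, it means among the compounds named here.

Measured so far in a physicochemical assay for solubility; on this read-out lower numbers stand for lower solubility and higher numbers for higher solubility:
- compound 1 `O=C(Nc1ccc([N+](=O)[O-])cc1)c1cc(Cl)ccc1O` gives 6.4 ug/mL
- compound 3 `O=C(Nc1ccc(F)c(Cl)c1)c1cc(Cl)ccc1O` gives 2.4 ug/mL
- compound 2 `O=C(Nc1ccc([N+](=O)[O-])c(Cl)c1)c1cc(Cl)ccc1O` gives only a limit of this assay, < 1 ug/mL

Compound 3 holds the lowest of the two numbers. The cores of compound 2 and compound 3 differ by fluoro in place of nitro on an aromatic carbon, which gave an at least 2.4-fold higher number from compound 2 to compound 3 (0.38 log units; beyond the scatter); this step is a bound because the limit of < 1 ug/mL in this assay, at which 1 of the 3 values shown sits, applies to compound 2. The change hydrogen in place of chloro on an aromatic carbon gave an at least 6.4-fold higher number from compound 2 to compound 1 (0.80 log units; beyond the scatter), again a bound because the limit of < 1 ug/mL in this assay, at which 1 of the 3 values shown sits, applies to compound 2.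

Compound 4 `O=C(Nc1ccc(F)cc1)c1cc(Cl)ccc1O` differs from compound 3 by hydrogen in place of chloro on an aromatic carbon. This is the same kind of change, though here the carbon is ortho to a fluoro group, whereas from compound 2 to compound 1 it was ortho to a nitro group. For compound 4 a step of a 5.0-fold higher number from compound 3 to compound 4 (0.70 log units; beyond the scatter) is expected, resting on an at least 6.4-fold higher number from compound 2 to compound 1 (0.80 log units; beyond the scatter) seen for compound 1. Compound 4 is estimated at 12 ug/mL, within 4 ug/mL to 35 ug/mL.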

Compound 4, solubility: 1.6 ug/mL
Estimate against measurement, compound 4: 7.5-fold (0.88 log units) above; measured number outside the range, below it.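

In this assay hydrogen in place of chloro on an aromatic carbon gave an at least 6.4-fold higher number from compound 2 to compound 1 (0.80 log units; beyond the scatter) with the nitro group present, yet a 1.5-fold lower number from compound 3 to compound 4 (0.18 log units; within the scatter) with the fluoro group present, so the rise seen in the first pair did not carry over to the second core. The first step is only a bound, as compound 2 stands at a limit of the assay: the limit of < 1 ug/mL in this assay, at which 1 of the 4 values shown sits. Fluoro in place of nitro on an aromatic carbon also depends on the core, with an at least 2.4-fold higher number from compound 2 to compound 3 (0.38 log units; beyond the scatter) set against a 4.0-fold lower number from compound 1 to compound 4 (0.60 log units; beyond the scatter) in the other direction, but these pairs do not show why, and no general rule follows from them.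

Open, going by these compounds, is how the chloro-to-hydrogen step runs with an amine or a carboxylic acid in place of the fluoro or nitro group. On these data alone, with no measured value for compound 2 beyond its limit, the true size of its steps also stays open.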